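This account rests on a few compounds, and the source may have more. Where it says the series, first, only, none or still open, it means among the compounds named here.

Two compounds share a core in which a benzyloxy group and a carbamoyl group carrying an aromatic ring sit on a benzene ring, with a third substituent at the remaining position. Compound 1 `O=C(Nc1ccnnc1)c1cc(N2CCCC2)ccc1OCc1ccccc1` carries a pyrrolidin-1-yl group there; compound 2 `O=C(Nc1cccnc1)c1cc(C(F)(F)F)ccc1OCc1ccccc1` carries a trifluoromethyl group and a pyridin-3-yl on the amide instead. In a physicochemical assay for lipophilicity, at pH 7.4 (a higher number here means a more lipophilic compound, a lower number a more polar compound), compound 1 gives 6.1, and compound 2 gives 6.3. The two numbers lie within the usual scatter of each other, so neither compound can be called the more lipophilic; both sit at a high level.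

Compound 3 `CN1CC2(CCN(c3ccc(OCc4ccccc4)c(C(=O)Nc4ccnnc4)c3)CC2)C1` keeps everything of compound 1 except the pyrrolidin-1-yl group, which is exchanged: a group of 10 heavy atoms (8 carbon, 2 nitrogen; one four-membered non-aromatic ring with 1 hetero atom, one six-membered non-aromatic ring with 1 hetero atom) in place of a group of 5 heavy atoms (4 carbon, 1 nitrogen; one five-membered non-aromatic ring with 1 hetero atom), on an aromatic carbon. Among the measured compounds shown here, no pair of measured compounds shows such a step, so its size can only be estimated. For this exchange the expected step in this assay is a number 1.80 log units lower from compound 1 to compound 3 (beyond the scatter), that is a decrease well beyond the scatter. For compound 3 the expected value in this assay is 4.3, with a likely range from 3.3 to 5.3.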

Compound 3, distribution coefficient: 2.2
Estimate against measurement, compound 3: 2.10 log units above, outside the stated range (below it).
By their numbers in this assay, from the lowest: compound 3; then compounds 1 and 2 (each within the scatter of the next).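

The position para to a benzyloxy group, on the aromatic carbon, turns out to have a strong hold on the reading in this assay: exchanging the pyrrolidin-1-yl group for the larger two-ring group gives a number 3.90 log units lower from compound 1 to compound 3 (beyond the scatter). Among the compounds shown here, this is the first single-place step, and it shows that the number at this position can move far, even though the entering group has more carbon atoms than the group that leaves, so for this pair a bigger group does not go with a higher number. Nothing shown here accounts for the size of this step.

One pair cannot tell which feature of the entering group carries the step: its second nitrogen, the methyl on that nitrogen, its four-membered ring or its overall size. From the compounds shown here alone, a plain piperidin-1-yl group or an N-methylpiperazin-1-yl group at the same position would help separate these features, and it also remains open whether the step would be the same with a pyridin-3-yl group on the amide in place of the pyridazin-4-yl group.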